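Methyl to Hydrogen on the Aromatic Oxygen: Estimating Compound 4

The source may report more compounds than this note shows. Statements on the series, on what has been measured and on what is new or still open speak of the compounds shown alone.

Measured compounds:
Compound 1, `CCc1oc2ccc(OC)cc2c1C(=O)c1ccc(O)cc1`, gives 2460 nM.
Compound 2, `CCc1oc2ccc(O)cc2c1C(=O)c1ccc(O)cc1`, gives 2490 nM.
Compound 3, `CCc1oc2ccc(OC)cc2c1C(=O)c1cc(Br)c(O)c(Br)c1`, gives 42 nM.

All three were tested in an assay for inhibition of solute carrier family 22 member 12 (Homo sapiens), read by scintillation counting, with a stated time of 60 min; on this read-out lower numbers stand for stronger inhibition and higher numbers for weaker inhibition. Compound 1 and compound 2 share everything except one small feature, shown here: hydrogen in place of methyl on an oxygen on an aromatic ring. That exchange left the read-out essentially unmoved, as the step of a 1.0-fold higher number from compound 1 to compound 2 (0.01 log units; within the scatter) shows, and the two values cannot be told apart within the usual spread of such measurements.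

Compound 3 differs from compound 1 in more than one place, so the difference between the two cores is not broken down here. What the numbers do show is that compound 3 sits far lower than either compound 1 or compound 2, with both gaps well beyond the scatter.

Compound 4, `CCc1oc2ccc(O)cc2c1C(=O)c1cc(Br)c(O)c(Br)c1`, has not yet been measured. It relates to compound 3 exactly as compound 2 relates to compound 1, by the following change: hydrogen in place of methyl on an oxygen on an aromatic ring. The surroundings of the altered site are described in identical words for both pairs, so this is the same change rather than merely a similar one.

Since that same change produced the step of a 1.0-fold higher number from compound 1 to compound 2 (0.01 log units; within the scatter), the expected step of a 1.1-fold higher number from compound 3 to compound 4 (0.03 log units; within the scatter) is likewise small. Compound 4 is therefore expected to give about 45 nM in this assay. The estimated range for compound 4 runs from 18 nM to 110 nM, allowing for the possibility that the change behaves differently on the dibrominated core of compound 3 than it did on the core of compound 1.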

Compound 4, half-maximal inhibitory concentration: 189 nM
Compound 4: middle estimate off by 4.2-fold (0.62 log units), on the low side; the measured number lies above the stated range.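

In this assay, the change from methoxy to hydroxy gave a 4.5-fold higher number from compound 3 to compound 4 (0.65 log units; beyond the scatter), so a swap that left the read-out essentially unmoved on the core of compound 1 did not do so on the core of compound 3. The size of a step measured on one core was therefore a poor guide to its size on the other in this series, and the gap between the two steps is real rather than a product of ordinary measurement spread: the same change on two cores in this assay, a 1.0-fold higher number (0.01 log units; within the scatter) from compound 1 to compound 2 and a 4.5-fold higher number (0.65 log units; beyond the scatter) from compound 3 to compound 4, 4.4-fold (0.65 log units) apart, beyond the scatter of two such steps These two pairs do not show why the cores respond differently, and they cannot say how the same change would behave on a third core.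

The compounds shown leave open what other groups on that aromatic oxygen would do, such as a longer chain like ethyl or propyl in place of the methyl, or what an amine or a carboxylic acid would do in place of the methoxy group. Also open, as far as these compounds go, is how the change from methoxy to hydroxy would behave with chlorine in place of bromine on the core of compound 3.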